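The source may report more compounds than this note shows. Statements on the series, on what has been measured and on what is new or still open speak of the compounds shown alone.

Measured in a functional assay on cells (Tumor Cell line, Homo sapiens) for cytotoxicity; a lower number here means a stronger inhibitor of growth, a higher number a weaker inhibitor of growth:
- compound 1 `Cc1cc(C)c2c(O)cc(-c3ccc(Cl)cc3)nc2n1`: 19500 nM
- compound 2 `COc1ccc(-c2cc(O)c3cccnc3n2)cc1`: 38000 nM
- compound 3 `Oc1cc(-c2ccc(Cl)cc2)nc2ncccc12`: 38900 nM

Compound 1 lies within the usual scatter of both other compounds, so these three numbers cannot be ranked. Compound 4 `COc1ccc(-c2cc(O)c3c(C)cc(C)nc3n2)cc1` differs from compound 1 in one place: methoxy in place of chloro on an aromatic carbon. This puts methoxy in place of chloro on an aromatic carbon, para to a large group. Among the compounds with values here, one measured step bears on this, the same swap in the opposite direction on a different core: a 1.0-fold higher number from compound 2 to compound 3 (0.01 log units; within the scatter). Within the data shown here, with so small a step as the only guide, no change beyond the scatter is expected in this assay. The expected step is a 1.0-fold higher number from compound 1 to compound 4 (0.01 log units; within the scatter). Compound 4 is estimated at 20000 nM, with an expected range of 10000 nM to 40000 nM.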

Compound 4, concentration for 50% growth inhibition: 33100 nM
Compound 4: the middle estimate sits 1.7-fold (0.22 log units) below what was measured; the measured number falls inside the stated range.
By their numbers in this assay, from the lowest: compounds 1, 4, 2 and 3 (each within the scatter of the next).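

In this assay, methoxy in place of chloro on an aromatic carbon, para to a large group, gives a 1.7-fold higher number from compound 1 to compound 4 (0.23 log units; within the scatter), so this swap now stays within the scatter on a second core as well. The two cores also do not separate from each other in how they respond to the swap: the same change on two cores in this assay, a 1.0-fold higher number (0.01 log units; within the scatter) from compound 2 to compound 3 and a 1.7-fold lower number (0.23 log units; within the scatter) from compound 4 to compound 1, 1.7-fold (0.24 log units) apart, within the scatter of two such steps

Going by these compounds, only chloro and methoxy appear at this place, so it remains open whether a different group there, such as an amine or a carboxylic acid, would give a step beyond the scatter.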